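Ethoxy in Place of Amino on a Carbonyl Carbon

A few compounds are considered here, and "the series" means these few. Any claim that something is new, unique, unknown or untested is made for them only; others in the source may bear on it.

Compound 1 `CC(C)(C)OC(=O)NCNC(=O)CN1CN(c2ccccc2)C2(CCN(C(=O)c3ccc(C4CCCCC4)cc3)CC2)C1=O` gives 1700 nM in an assay on HEK293 cells for displacement of a labelled ligand from NPC1-like intracellular cholesterol transporter 1 (Homo sapiens); on this read-out higher numbers stand for weaker inhibition and lower numbers for stronger inhibition.
Compound 2 `CC1CCCN(C(=O)CN2CN(c3ccccc3)C3(CCN(C(=O)c4ccc(C5CCCCC5)cc4)CC3)C2=O)C1` gives 3600 nM in this assay.
Compound 3 `NC(=O)C1CCCN(C(=O)CN2CN(c3ccccc3)C3(CCN(C(=O)c4ccc(C5CCCCC5)cc4)CC3)C2=O)C1` gives 3100 nM in this assay.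

Compound 3 holds the second highest number of the three. Its nearest neighbour is compound 2, at a 1.2-fold lower number from compound 2 to compound 3 (0.06 log units; within the scatter); its furthest is compound 1, at a 1.8-fold higher number from compound 1 to compound 3 (0.26 log units; within the scatter). Both gaps lie within the scatter, so compound 3 cannot be set apart from either.

Compound 4 `CCOC(=O)C1CCCN(C(=O)CN2CN(c3ccccc3)C3(CCN(C(=O)c4ccc(C5CCCCC5)cc4)CC3)C2=O)C1` differs from compound 3 in one place: ethoxy in place of amino on a carbonyl carbon. Going by the values given here, no measured step changes this group, so the guide is indirect. The change of a carbamoyl into a methyl on a saturated ring carbon, a 1.2-fold lower number from compound 2 to compound 3 (0.06 log units; within the scatter), stayed within the scatter, and the replacement of the whole carbonyl substituent, a 1.8-fold higher number from compound 1 to compound 3 (0.26 log units; within the scatter), stayed within the scatter as well. The shared core tolerates these edits without a clear shift. In this assay the step of a 1.0-fold lower number from compound 3 to compound 4 (0.01 log units; within the scatter) is therefore expected to stay within the scatter. Compound 4 is estimated at 3000 nM, with a range from 1500 nM to 6000 nM.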

Compound 4, half-maximal inhibitory concentration: 4200 nM
The estimate for compound 4 lay 1.4-fold (0.15 log units) below the measured number, and the stated range covers the measured number.
By their numbers in this assay, from the lowest: compounds 1, 3, 2 and 4 (each within the scatter of the next, the first and the last beyond it).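

In this assay, ethoxy on the carbonyl carbon in place of amino removes the hydrogen-bond donor of the carbamoyl and adds two heavy atoms, yet the result is a 1.4-fold higher number from compound 3 to compound 4 (0.13 log units; within the scatter) and the carbamoyl gives no measurable advantage over the ester. Ethoxycarbonyl on the saturated ring carbon also reads level with methyl, at a 1.2-fold higher number from compound 2 to compound 4 (0.07 log units; within the scatter), so methyl, carbamoyl and ethoxycarbonyl cannot be told apart at this position. Only the replacement of the whole carbonyl substituent clears the scatter, with a 2.5-fold higher number from compound 1 to compound 4 (0.39 log units; beyond the scatter), a modest step that spans the full width of the series.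

No measurement at hand accounts for this flat response. Going by these compounds, whether a carboxylic acid or an amine on this ring carbon would stay level with these groups remains open.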